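A few compounds are considered here, and "the series" means these few. Any claim that something is new, unique, unknown or untested is made for them only; others in the source may bear on it.

Of the compounds shown here, three built on one shared core have been tested in an ADME assay on HOS cells (Homo sapiens) for cytotoxicity; a higher number here means that more compound is tolerated, a lower number that less compound is tolerated. Compound 1 `CN(C)[C@@H]1CCN(c2cccc3nc(CN(C)[C@H]4CCCc5cccnc54)cn23)C1` gives 4900 nM in this assay, compound 2 `CN(C)C1CCN(c2cccc3nc(CN(C)[C@H]4CCCc5cccnc54)cn23)CC1` gives 3400 nM, and compound 3 `CC(C)N1CCN(c2cccc3nc(CN(C)[C@H]4CCCc5cccnc54)cn23)CC1` gives 7100 nM. Compound 3 thus holds the highest number of the three: a 1.4-fold higher number from compound 1 to compound 3 (0.16 log units; within the scatter), while a 2.1-fold higher number from compound 2 to compound 3 (0.32 log units; beyond the scatter). Compound 4 `CN(Cc1cn2c(N3CCC(N)CC3)cccc2n1)[C@H]1CCCc2cccnc21` differs from compound 3 in a single place: 4-aminopiperidin-1-yl in place of 4-isopropylpiperazin-1-yl on an aromatic carbon The step of a 2.1-fold higher number from compound 2 to compound 3 (0.32 log units; beyond the scatter) bears most on this change: compound 4 carries a 4-aminopiperidin-1-yl group, which sits closer to the 4-(dimethylamino)piperidin-1-yl of compound 2 than to the 4-isopropylpiperazin-1-yl of compound 3. A modest move toward compound 2 is therefore expected, a 1.8-fold lower number from compound 3 to compound 4 (0.25 log units; within the scatter). Compound 4 is estimated at 4000 nM, within a range from 1800 nM to 9000 nM.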

Compound 4, half-maximal cytotoxic concentration: 6300 nM
Compound 4: the middle estimate sits 1.6-fold (0.20 log units) below what was measured; the range from low to high includes it.
By their numbers in this assay, from the lowest: compounds 2, 1, 4 and 3 (each within the scatter of the next, the first and the last beyond it).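

In this assay, the position on the aromatic carbon next to the ring nitrogen takes 4-aminopiperidin-1-yl, with its hydrogen-bond donor, as readily as 4-isopropylpiperazin-1-yl: a 1.1-fold lower number from compound 3 to compound 4 (0.05 log units; within the scatter). Amino in place of dimethylamino on a saturated ring carbon also gives no readable change, a 1.9-fold higher number from compound 2 to compound 4 (0.27 log units; within the scatter), and neither does the swap from 3-(dimethylamino)pyrrolidin-1-yl, a 1.3-fold higher number from compound 1 to compound 4 (0.11 log units; within the scatter). Nothing available explains these numbers. As far as these compounds go, whether a carboxylic acid or a morpholine ring at this position would move the number beyond the scatter remains open.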